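The source may report more compounds than this note shows. Statements on the series, on what has been measured and on what is new or still open speak of the compounds shown alone.

Compound 3 `CC(C)Cc1ccc(C(C)c2nnc3n2N=C(c2ccc(OC(F)(F)F)cc2)CS3)cc1` gives the lowest number of the three compounds tested in a functional assay on HCT-116 cells (Homo sapiens) for inhibition, read by sulforhodamine B assay, with a stated time of 72 h; on this read-out lower numbers stand for stronger inhibition and higher numbers for weaker inhibition: compound 3 gives 3000 nM, while compound 2 `COc1ccc2cc(C(C)c3nnc4n3N=C(c3ccc(C)cc3)CS4)ccc2c1` gives 10200 nM and compound 1 `COc1ccc2cc(C(C)c3nnc4n3N=C(c3ccc(Cl)cc3Cl)CS4)ccc2c1` gives 14000 nM. Compound 4 `CC(C)Cc1ccc(C(C)c2nnc3n2N=C(c2ccc(Br)cc2)CS3)cc1` differs from compound 3 in one place: bromo in place of trifluoromethoxy on an aromatic carbon. Going by the values given here, the only measured step that alters a group on an aromatic ring is a 1.4-fold lower number from compound 1 to compound 2 (0.14 log units; within the scatter), and it exchanges one whole substituted phenyl for another rather than a single group, so it bears on the present change only loosely. With no closer comparison available, the expected step is none beyond the scatter, a 1.2-fold higher number from compound 3 to compound 4 (0.07 log units; within the scatter). Compound 4 is therefore estimated to give about 3500 nM in this assay, with a range from 1500 nM to 9000 nM.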

Compound 4, half-maximal inhibitory concentration: 7100 nM
Estimate against measurement, compound 4: 2.0-fold (0.31 log units) below; low and high end bracket the measured number.
By their numbers in this assay, from the lowest: compound 3; then compounds 4, 2 and 1 (each within the scatter of the next).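

Putting bromo in place of trifluoromethoxy on this aromatic carbon gives a 2.4-fold higher number from compound 3 to compound 4 (0.37 log units; beyond the scatter) and so shows that changing this single group can move the number beyond the usual scatter, though only modestly. Going by these compounds alone, the one earlier step exchanged a whole substituted phenyl and stayed within the scatter. No measurement on either group is available to explain the difference. From the compounds shown here alone, whether an amine or a carboxylic acid on this carbon would give a lower or higher number stays open. So does whether the same exchange would have a similar effect with the other side group seen in compound 1 and compound 2.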